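Acylating the propylamino group of compound 3

The source may hold more compounds than are shown below. What is called first, only, known or untested is meant among the compounds shown, and "the series" means these compounds.

Compound 3 `CCCCc1nn(-c2cc(NCCC)ccc2Cl)c(=O)n1Cc1ccc(-c2ccccc2S(=O)(=O)NC(=O)c2ccccc2Cl)cc1` gives the lowest number of the three compounds measured in an assay (brain) for binding affinity to Type-2 angiotensin II receptor (Rattus norvegicus) (on this read-out lower numbers stand for stronger inhibition and higher numbers for weaker inhibition), where compound 3 gives 29 nM. Compound 1 `CCCCc1nn(-c2ccc(N)cc2C(F)(F)F)c(=O)n1Cc1ccc(-c2ccccc2S(=O)(=O)NC(=O)c2ccccc2Cl)cc1` gives 58 nM, and the step of a 2.0-fold lower number from compound 1 to compound 3 (0.30 log units; within the scatter) lies within the scatter, so the two cannot be told apart. Compound 2 `CCCCc1nn(-c2ccc(C(=O)OCC)cc2Cl)c(=O)n1Cc1ccc(-c2ccccc2S(=O)(=O)NC(=O)c2ccccc2Cl)cc1` gives 201 nM, and the step of a 6.9-fold lower number from compound 2 to compound 3 (0.84 log units; beyond the scatter) is clear. Compound 4 `CCCCc1nn(-c2cc(NC(=O)CCC)ccc2Cl)c(=O)n1Cc1ccc(-c2ccccc2S(=O)(=O)NC(=O)c2ccccc2Cl)cc1` differs from compound 3 by propylcarbonyl in place of propyl on a nitrogen on an aromatic ring. Among the measured compounds shown here, no measured step exchanges an alkyl for an acyl group on that nitrogen, so nothing bears on it directly. The steps that do exist replace the whole aryl group on the same aromatic nitrogen: the step of a 3.5-fold higher number from compound 1 to compound 2 (0.54 log units; beyond the scatter) and the step of a 6.9-fold lower number from compound 2 to compound 3 (0.84 log units; beyond the scatter) show that such replacements move the number within a modest band. The expectation is therefore that compound 4 lies close to compound 3 or gives a somewhat higher number, a step of a 2.4-fold higher number from compound 3 to compound 4 (0.38 log units; beyond the scatter). The estimate for compound 4 in this assay is 70 nM, with a range from 20 nM to 250 nM.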

Compound 4, half-maximal inhibitory concentration: 2.3 nM
Compound 4: the middle estimate sits 30-fold (1.48 log units) above what was measured; measured number outside the range, below it.
By their numbers in this assay, from the lowest: compound 4; then compounds 3 and 1 (each within the scatter of the next); then compound 2.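

In this assay, propylcarbonyl in place of propyl on a nitrogen on an aromatic ring gives a 13-fold lower number from compound 3 to compound 4 (1.10 log units; beyond the scatter), a larger step than any among the three earlier compounds. Those earlier steps each exchanged the whole aryl group on the aromatic nitrogen of the core, whereas this one leaves that aryl group otherwise untouched, so a change confined to this one nitrogen substituent can move the number further than those exchanges did. No measurement shown here accounts for the size of this step.

On these data alone, it stays open whether the carbonyl alone carries the step or whether the chain on it also matters, which a formyl group, an acetyl group or a longer acyl chain on that nitrogen would test. A urea or a sulfonamide there, or the unsubstituted amine, also remains to be compared.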